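From Naphthalen-1-yl to Phenyl in Compound 4

The source may report more compounds than this note shows. Statements on the series, on what has been measured and on what is new or still open speak of the compounds shown alone.

In a functional assay on HL-60 cells (Homo sapiens) for inhibition, read by CCK-8 assay, with a stated time of 48 h, tested at 20 uM (a lower number here means less inhibition of growth, a higher number more inhibition of growth at the concentration tested), compound 2 `COc1ccc(S(=O)(=O)Oc2ccccc2/C=C(\C#N)C(=O)Nc2nnc(Cc3cccc4ccccc34)s2)cc1` gives 98%. This lies within the scatter of compound 1 `COc1ccc(Cc2nnc(NC(=O)/C(C#N)=C/c3ccccc3OS(=O)(=O)c3ccc(OC)cc3)s2)cc1` at 100% and well above compound 3 `N#C/C(=C\c1ccccc1OS(=O)(=O)c1ccc(F)cc1)C(=O)Nc1nnc(Cc2cccc3ccccc23)s1` at 12%. Compound 4 `COc1ccc(S(=O)(=O)Oc2ccccc2/C=C(\C#N)C(=O)Nc2nnc(Cc3ccccc3)s2)cc1` differs from compound 2 at one place, (phenyl in place of naphthalen-1-yl on a saturated chain carbon bound to an aromatic carbon), with phenyl in place of naphthalen-1-yl on a saturated chain carbon bound to an aromatic carbon. For the measured compounds named here, the one measured change at this place, a number 2 percentage points lower from compound 1 to compound 2 (within the scatter), stayed within the scatter. The other measured step, a number 86 percentage points lower from compound 2 to compound 3 (beyond the scatter), was large, but compound 4 keeps the methoxy. No step beyond the scatter is therefore expected, and the estimated change is a number 6 percentage points lower from compound 2 to compound 4 (within the scatter). Compound 4 is estimated at 92%, with an expected range from 70% to 100%.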

Compound 4, percent growth inhibition at one concentration: 100%
Compound 4: the middle estimate sits 8 percentage points below what was measured, within the range that was stated.
By their numbers in this assay, from the lowest: compound 3; then compounds 2, 1 and 4 (each within the scatter of the next).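

In this assay, benzyl serves as well as (naphthalen-1-yl)methyl, with a number 2 percentage points higher from compound 2 to compound 4 (within the scatter), so the second six-membered aromatic ring is not needed for growth inhibition at the concentration tested. The methoxy of the 4-methoxyphenyl group is not needed either, with no change at the digits printed from compound 1 to compound 4 (within the scatter). Nothing available gives a reason for this tolerance. On these data alone, whether this position also accepts a phenyl group carrying an amine or a carboxylic acid remains open. So does whether compound 1, compound 2 and compound 4 would separate at a lower concentration.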